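The compounds below may be only part of what the source reports. "The series", "measured", "known", "first", "only" and "open" are said of these compounds alone.

Compound 1 `Cc1cc(C)c(CN2CCc3c(Cl)cc([C@H](CO)[C@H]4CCOC4)c(Cl)c3C2=O)c(=O)[nH]1` and compound 2 `Cc1cc(C)c(CN2CCc3c(Cl)cc([C@H](CO)[C@H]4CCCO4)c(Cl)c3C2=O)c(=O)[nH]1` share one core and differ only in the ring attached to the chain carbon. In an ADME assay on microsomes from liver (Homo sapiens) for metabolic stability, read by LC-MS, using NADPH, with stated times of 10 min and 45 min, tested at 1 uM (on this read-out higher numbers stand for fast clearance and lower numbers for slow clearance), compound 1 gives 21.3 uL/min, and compound 2 gives 51.6 uL/min; that step, a 2.4-fold higher number from compound 1 to compound 2 (0.38 log units; beyond the scatter), puts compound 2 at the higher of the two numbers. Compound 3 `Cc1cc(C)c(CN2CCc3c(Cl)cc([C@H](CO)[C@@H]4CCCO4)c(Cl)c3C2=O)c(=O)[nH]1` keeps every atom and bond of compound 2: the two compounds have the same atoms and bonds and differ only in configuration as drawn: 1 of 2 stereo elements differ; a stereocentre at a saturated ring carbon is drawn R in compound 2 and S in compound 3. For the measured compounds named here, no measured step here changes only a stereocentre, so nothing bears directly on this change, and the step of a 1.1-fold lower number from compound 2 to compound 3 (0.06 log units; within the scatter) is expected to stay within the scatter. Compound 3 is therefore estimated at 45 uL/min, within 22 uL/min to 90 uL/min.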

Compound 3, intrinsic clearance in a liver preparation (reported as CLH), per the amount of preparation that the assay uses: 37.6 uL/min
Compound 3: the middle estimate sits 1.2-fold (0.08 log units) above what was measured; measured number inside the range.
By their numbers in this assay, from the lowest: compounds 1, 3 and 2 (each within the scatter of the next, the first and the last beyond it).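

In this assay the inverted ring carbon gives a 1.4-fold lower number from compound 2 to compound 3 (0.14 log units; within the scatter) and so, at this position, the drawn configuration of the oxolan-2-yl ring shifts clearance by no more than repeat measurements would. Replacing oxolan-3-yl now gives a 1.8-fold higher number from compound 1 to compound 3 (0.25 log units; within the scatter) and so, unlike the step to compound 2, this swap does not clear the scatter. This pair isolates a single change: the fact that compounds 2 and 3 differ only in the configuration as drawn. Still open, from the compounds shown here alone, is how the other drawn configuration of the oxolan-3-yl ring would read, and whether an amine or an open methoxyethyl chain in place of the ring would shift clearance further.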